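A few compounds are considered here, and "the series" means these few. Any claim that something is new, unique, unknown or untested is made for them only; others in the source may bear on it.

Compound 1 `CCn1ncc(-c2nc3c(N4CCC(n5c(=O)[nH]c6ncccc65)CC4)ncnc3n2C)c1C`: 76%
Compound 2 `CCn1ncc(-c2nc3c(O[C@H]4CCN(C(=O)C5CC5)C4)ncnc3n2C)c1C`: 52%

Both compounds share one core and have been run in an ADME assay on the whole organism (Rattus norvegicus, strain Wistar Han) for pharmacokinetics; on this read-out higher numbers stand for higher oral bioavailability and lower numbers for lower oral bioavailability. Compound 2 stands lowest of the two numbers; its nearest neighbour is compound 1, whose value lies higher by a margin beyond the scatter. Compound 3 `CCn1ncc(-c2nc3c(O[C@H]4CCN(C(=O)C5CCOCC5)C4)ncnc3n2C)c1C` has not yet been measured. It differs from compound 2 by oxan-4-yl in place of cyclopropyl on a carbonyl carbon. Among the measured compounds shown here, no step between measured compounds covers this change, so the data give no guide to its size. A small decrease, or none beyond the scatter, is expected, the step being a number 4 percentage points lower from compound 2 to compound 3 (within the scatter). Compound 3 is estimated at 48%, with a range from 28% to 70%.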

Compound 3, oral bioavailability: 55%
Compound 3: middle estimate off by 7 percentage points, on the low side, within the range that was stated.
By their numbers in this assay, from the lowest: compounds 2 and 3 (each within the scatter of the next); then compound 1.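

In this assay the step on the carbonyl carbon, a number 3 percentage points higher from compound 2 to compound 3 (within the scatter), shows that oxan-4-yl, with its six heavy atoms and one hydrogen-bond acceptor, and cyclopropyl cannot be told apart at this position. Among the compounds shown here, only this single pair speaks to the carbonyl substituent, so the finding holds for these two rings alone. No measurement shown offers an explanation for this result. Open, from the compounds shown here alone, is how an amine such as piperidin-4-yl, a carboxylic acid or a longer alkyl chain on this carbonyl carbon would read. Also open, going by these compounds, is whether any substituent here can move the number beyond the scatter.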